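The compounds below may be only part of what the source reports. "The series", "measured", "known", "first", "only" and "open" are said of these compounds alone.

In a functional assay on HL-60 cells (Homo sapiens) for antiproliferative activity, with a stated time of 24 h (on this read-out lower numbers stand for stronger inhibition and higher numbers for weaker inhibition), compound 1 `Cc1ccc(C(=O)Nc2sc3c(c2C(N)=O)CCN(Cc2c(Cl)cccc2Cl)C3)cc1` gives 10000 nM. In this assay compound 2 `NC(=O)c1c(NC(=O)c2cccc([N+](=O)[O-])c2)sc2c1CCN(Cc1c(Cl)cccc1Cl)C2` gives 18400 nM. In this assay compound 3 `Cc1ccc(C(=O)Nc2sc3c(c2C(N)=O)CCN(C(=S)Nc2ccccc2Cl)C3)cc1` gives 8430 nM.

All three compounds share a core; they differ in two groups attached to it. Compound 2 differs from compound 1 in 3-nitrophenyl in place of 4-methylphenyl on a carbonyl carbon. That change gave a 1.8-fold higher number from compound 1 to compound 2 (0.26 log units; within the scatter). Compound 3 differs from compound 1 in a group of 10 heavy atoms (7 carbon, 1 nitrogen, 1 sulfur, 1 chlorine; one six-membered aromatic ring of carbon only) in place of a group of 9 heavy atoms (7 carbon, 2 chlorine; one six-membered aromatic ring of carbon only), on an amine nitrogen in a ring. That change gave a 1.2-fold lower number from compound 1 to compound 3 (0.07 log units; within the scatter). Neither step stands out from the scatter of repeated measurements.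

Compound 4 `NC(=O)c1c(NC(=O)c2cccc([N+](=O)[O-])c2)sc2c1CCN(C(=S)Nc1ccccc1Cl)C2` has not yet been measured in this assay. It differs from compound 3 in 3-nitrophenyl in place of 4-methylphenyl on a carbonyl carbon. This is the same change that turns compound 1 into compound 2, and its place is described in the same words in both pairs. What sets the two pairs apart is their cores: compound 3 and compound 4 carry the group that enters in going from compound 1 to compound 3, in place of the 2,6-dichlorobenzyl group.

Since the change has been seen once, with a step inside the scatter, a similar small step is expected here. The step from compound 3 to compound 4 is expected to be about a 1.8-fold higher number from compound 3 to compound 4 (0.25 log units; within the scatter). Compound 4 is therefore expected to give about 15000 nM in this assay, most likely between 7000 nM and 32000 nM.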

Compound 4, half-maximal inhibitory concentration: 7040 nM
Compound 4: middle estimate off by 2.1-fold (0.33 log units), on the high side; the measured number falls inside the stated range.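

In this assay, 3-nitrophenyl in place of 4-methylphenyl on a carbonyl carbon gives a 1.2-fold lower number from compound 3 to compound 4 (0.08 log units; within the scatter), and this step does not differ beyond the scatter from the earlier step for the same change: the same change on two cores in this assay, a 1.8-fold higher number (0.26 log units; within the scatter) from compound 1 to compound 2 and a 1.2-fold lower number (0.08 log units; within the scatter) from compound 3 to compound 4, 2.2-fold (0.34 log units) apart, within the scatter of two such steps Replacing the 2,6-dichlorobenzyl group with the sulfur-bearing group on an amine nitrogen in a ring gives a 2.6-fold lower number from compound 2 to compound 4 (0.42 log units; beyond the scatter), a modest step beyond the scatter, yet it too stays within the scatter of its earlier counterpart: the same change on two cores in this assay, a 1.2-fold lower number (0.07 log units; within the scatter) from compound 1 to compound 3 and a 2.6-fold lower number (0.42 log units; beyond the scatter) from compound 2 to compound 4, 2.2-fold (0.34 log units) apart, within the scatter of two such steps In these four compounds, then, neither change behaves differently on the two cores by more than the scatter allows; this does not show that either change would carry over the same way to further cores, as each has been seen only twice and most of the steps are themselves small.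

The compounds shown leave open how other groups on the carbonyl carbon would behave, such as a phenyl ring carrying an amine or a carboxylic acid. They also leave open whether a longer carbon chain on the amine nitrogen in the ring would give a step that carries between cores in the same way.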